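The compounds below may be only part of what the source reports. "The series", "measured", "known", "first", "only" and "open" are said of these compounds alone.

In a functional assay on MCF7 cells (Homo sapiens) for cytotoxicity, read by MTT assay, with a stated time of 96 h (on this read-out lower numbers stand for stronger inhibition and higher numbers for weaker inhibition), compound 1 `COc1cc(C(=O)c2cn(-c3ccc(Cl)cc3)cc2-c2ccccc2)cc(OC)c1OC` gives 140 nM and compound 2 `COc1cc(C(=O)c2cn(-c3ccc([N+](=O)[O-])cc3)cc2-c2ccccc2)cc(OC)c1OC` gives 4000 nM, the higher of the two numbers, which puts compound 2 at the weak end of this short series. Compound 3 `COc1cc(C(=O)c2cn(-c3ccc(N)cc3)cc2-c2ccccc2)cc(OC)c1OC` keeps the shared core and carries amino in place of nitro on an aromatic carbon, para to a large group: amino in place of nitro on an aromatic carbon. Within the data shown here, only one measured step bears on this change: a 29-fold higher number from compound 1 to compound 2 (1.46 log units; beyond the scatter), with nitro in place of chloro. Nitro is the group that leaves here, but no amino compound has been measured, so that step gives direction better than size. A large move towards a lower number is expected in this assay. The expected change is a 44-fold lower number from compound 2 to compound 3 (1.65 log units; beyond the scatter). Compound 3 is estimated at 90 nM, with an expected range of 15 nM to 550 nM.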

Compound 3, half-maximal inhibitory concentration: 35 nM
The estimate for compound 3 lay 2.6-fold (0.41 log units) above the measured number, and the stated range covers the measured number.
By their numbers in this assay, from the lowest: compound 3; then compound 1; then compound 2.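

In this assay this aromatic carbon, para to a large group, spans a wider range than the first pair showed: amino in place of nitro gives a 110-fold lower number from compound 2 to compound 3 (2.06 log units; beyond the scatter) and takes the number past that of the chloro compound. Amino in place of chloro gives a 4.0-fold lower number from compound 1 to compound 3 (0.60 log units; beyond the scatter) and puts amino, rather than chloro, at the low end of the three groups compared here. No measurement at hand accounts for either step.

Going by these compounds, whether a methylamino group, a dimethylamino group, an acetamide or a hydroxyl group at the same place would keep or lose the low number stays open. Among these compounds, with only three groups at this position and a single cell line, the order cannot yet be read as a trend beyond these compounds.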